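The source may report more compounds than this note shows. Statements on the series, on what has been measured and on what is new or still open speak of the compounds shown alone.

Within the data shown here, in a physicochemical assay for lipophilicity, measured as octanol-water partition, at pH 7.4 (a higher number here means a more lipophilic compound, a lower number a more polar compound), compound 2 (`O=C([C@H](O)CS(=O)(=O)c1ccc2cc(Cl)ccc2c1)N1CCC(N2CCNC2=O)CC1`) gives 1.73, the lower of the two numbers so far. Among the measured compounds shown here, the only other measured compound, compound 1 (`O=C([C@H](O)CS(=O)(=O)c1ccc2cc(Cl)ccc2c1)N1CCC(N2Cc3cccn3C2=O)CC1`), gives 2.6. Compound 3 (`O=C([C@H](O)CS(=O)(=O)c1ccc2cc(Cl)ccc2c1)N1CCC(n2cc[nH]c2=O)CC1`) keeps the shared core and changes one group: a group of 6 heavy atoms (3 carbon, 2 nitrogen, 1 oxygen; one five-membered aromatic ring with 2 hetero atoms) in place of a group of 6 heavy atoms (3 carbon, 2 nitrogen, 1 oxygen; one five-membered non-aromatic ring with 2 hetero atoms), on a saturated ring carbon. A five-membered non-aromatic ring gives way to a five-membered aromatic ring, on a saturated ring carbon. For the measured compounds named here, one measured step bears on this, and only loosely: a number 0.87 log units lower from compound 1 to compound 2 (beyond the scatter), modest and beyond the scatter. That step replaced a larger group with a smaller one, which the present change does not do, so its size does not carry over. No step beyond the scatter is therefore expected in this assay, only a slight upward drift. The expected step is a number 0.17 log units higher from compound 2 to compound 3 (within the scatter). For compound 3 the estimate is 1.9, with an expected range from 1.5 to 2.4.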

Compound 3, distribution coefficient: 1.79
Beside the measured number, compound 3's estimate is 0.11 log units above it; the measured number falls inside the stated range.
By their numbers in this assay, from the lowest: compounds 2 and 3 (each within the scatter of the next); then compound 1.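

In this assay, the five-membered aromatic ring and the 2-oxoimidazolidin-1-yl group it replaces cannot be told apart on this saturated ring carbon: a number 0.06 log units higher from compound 2 to compound 3 (within the scatter). The difference from the larger group of compound 1 also recurs with the aromatic ring, a number 0.81 log units lower from compound 1 to compound 3 (beyond the scatter), so this second group of 6 heavy atoms stands with compound 2 rather than compound 1. At this position, then, going from a non-aromatic to an aromatic ring with the same heavy-atom count does not move the number beyond the scatter, and nothing available explains this result. The compounds shown leave open what a primary amine, a carboxylic acid or a longer chain would give on this carbon. They also leave open whether the same ring change would behave alike on a different core.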